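Benzyl amide in place of dimethylphenyl on the methoxy core

This account rests on a few compounds, and the source may have more. Where it says the series, first, only, none or still open, it means among the compounds named here.

Compound 1 `COc1ccc2c(=O)c(/C=C/C(=O)Nc3cc(C)ccc3C)coc2c1` gives 15500 nM in a functional assay on A549 cells (Homo sapiens) for inhibition, read by MTT assay, with a stated time of 48 h (a lower number here means a stronger inhibitor, a higher number a weaker inhibitor), the lowest of the two numbers in hand; compound 3 `Cc1ccc(CNC(=O)/C=C/c2coc3cc(O)ccc3c2=O)cc1` sits within the scatter of it at 17400 nM. Compound 2 `Cc1ccccc1NC(=O)/C=C/c1coc2cc(O)ccc2c1=O` reaches only a limit of this assay, > 100000 nM. The step from compound 2 to compound 3 is an at least 5.7-fold lower number from compound 2 to compound 3 (0.75 log units; beyond the scatter), but this rests on the limit of > 100000 nM in this assay, at which 1 of the 3 values shown sits, and its true size is open.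

Compound 4 `COc1ccc2c(=O)c(/C=C/C(=O)NCc3ccccc3)coc2c1` is not yet measured. It differs from compound 1 by benzyl in place of 2,5-dimethylphenyl on an amide-type nitrogen. Going by the values given here, the one measured step that bears on this kind of change, from an aryl amide to a benzyl-type amide, is an at least 5.7-fold lower number from compound 2 to compound 3 (0.75 log units; beyond the scatter), pointing to a lower number. Yet compound 3, which already carries a benzyl-type amide, stands at 17400 nM, no better than compound 1 at 15500 nM, so the gain seen there need not carry over on a core whose aryl amide is already well inside the measurable range.

On balance a modest move toward a lower number is expected, a 1.9-fold lower number from compound 1 to compound 4 (0.29 log units; within the scatter). Compound 4 is therefore estimated at 8000 nM, with a range from 2500 nM to 25000 nM.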

Compound 4, half-maximal inhibitory concentration: 11800 nM
Compound 4: the middle estimate sits 1.5-fold (0.17 log units) below what was measured; the range from low to high includes it.
By their numbers in this assay, from the lowest: compounds 4, 1 and 3 (each within the scatter of the next). At a limit, above all of these: compound 2.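

On the amide-type nitrogen of the core of compound 1, benzyl in place of 2,5-dimethylphenyl gives a 1.3-fold lower number from compound 1 to compound 4 (0.12 log units; within the scatter) in this assay, so on this core the two groups cannot be told apart at this position. The earlier compounds shown here showed a change from an aryl amide to a benzyl-type amide only on a different core, as an at least 5.7-fold lower number from compound 2 to compound 3 (0.75 log units; beyond the scatter), and the new step shows that a step beyond the scatter does not recur with the related change on the core of compound 1. Compound 2 stands at a limit in this assay, so the earlier step has no fixed size and cannot be set against the new one by size: the limit of > 100000 nM in this assay, at which 1 of the 4 values shown sits.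

Open, as far as these compounds go, is whether a longer chain such as 2-phenylethyl, or a dimethylaminoethyl group, on the amide-type nitrogen would move the number beyond the scatter of compound 1 and compound 4. Also open, from the compounds shown here alone, is whether one and the same pair of groups gives the same step on both cores, as the two steps in hand involve different groups.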